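The source may report more compounds than this note shows. Statements on the series, on what has been measured and on what is new or still open speak of the compounds shown alone.

Measured so far:
compound 1 `CCCCOC(=O)NS(=O)(=O)c1ccc(CCC)cc1-c1ccc(Cn2c(C3CCCCC3)nc3ccccc32)cc1` — 130 nM
compound 2 `CCCc1ccc(S(=O)(=O)NC(=O)OCCCC(F)(F)F)c(-c2cc(F)c(Cn3c(C(C)(C)C)nc4ccccc43)c(F)c2)c1` — 12 nM

In an assay on membranes from HEK293 cells for displacement of a labelled ligand from Type-2 angiotensin II receptor (Homo sapiens), read by radioligand binding (on this read-out lower numbers stand for stronger inhibition and higher numbers for weaker inhibition), compound 2 gives the lowest of the two numbers in hand; compound 1 sits a gap away in the weaker direction, a difference beyond the scatter of repeated runs. Going by the values given here, no single-place step between measured compounds is available, so the comparison of compound 1 with compound 2 shows only what its two values show.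

Compound 3 `CCCCOC(=O)NS(=O)(=O)c1ccc(CCC)cc1-c1cc(F)c(Cn2c(C(C)(C)C)nc3ccccc32)c(F)c1` is not yet measured in this assay. It follows from compound 2 by one change: methyl in place of trifluoromethyl on a saturated chain carbon, three bonds along the chain from an oxygen next to a carbonyl group. The rest of compound 2 is kept unchanged. Among the compounds with values here, with no measured pair isolating this change, the size of the step is uncertain; the expectation is a small move, likely within the scatter, with a slight lean toward a higher number.

Compound 3 is expected to give about 18 nM in this assay, within a range of 6 nM to 55 nM. The step of a 1.5-fold higher number from compound 2 to compound 3 (0.18 log units; within the scatter) is thus expected to be modest.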

Compound 3, inhibition constant: 11 nM
Compound 3: the middle estimate sits 1.6-fold (0.21 log units) above what was measured, within the range that was stated.
By their numbers in this assay, from the lowest: compounds 3 and 2 (each within the scatter of the next); then compound 1.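

In this assay, going by these compounds alone, the exchange of 4,4,4-trifluorobutyl for butyl gives a 1.1-fold lower number from compound 2 to compound 3 (0.04 log units; within the scatter), the only single-place step in hand. On a saturated chain carbon, three bonds along the chain from an oxygen next to a carbonyl group, methyl and trifluoromethyl therefore cannot be told apart on this read-out, and the three fluorine atoms are not required for a value of this size. No measurement in hand gives a reason for this result.

As far as these compounds go, whether the position accepts other kinds of group stays open: a longer chain, a hydroxyl, an amine or a carboxylic acid at the chain end would each test this. Also open, from the compounds shown here alone, is whether the same exchange reads the same way on the core of compound 1.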